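The source may hold more compounds than are shown below. What is called first, only, known or untested is meant among the compounds shown, and "the series" means these compounds.

Measured compounds and their values:

Compound 1 `CC1=CC[C@@H]([C@@](C)(O)CCCC(C)(C)NC(=S)NN)CC1` gives 17200 nM in a functional assay on OVCAR-3 cells (Homo sapiens) for cytotoxicity, read by sulforhodamine B assay; on this read-out higher numbers stand for weaker inhibition of growth and lower numbers for stronger inhibition of growth.
Compound 2 `CC1=CC[C@@H]([C@@](C)(O)CCCC(C)(C)NC(=S)N/N=C\c2ccccc2)CC1` gives 6970 nM in this assay.
Compound 3 `CC1=CC[C@@H]([C@@](C)(O)CCCC(C)(C)NC(=S)N/N=C\c2ccc(Cl)cc2)CC1` gives 6660 nM in this assay.

Compound 3 holds the lowest number of the three; its gap to compound 2 lies within the scatter, so the two cannot be ranked, while the step of a 2.6-fold lower number from compound 1 to compound 3 (0.41 log units; beyond the scatter) does stand out. Compound 4 `CC1=CC[C@@H]([C@@](C)(O)CCCC(C)(C)NC(=S)N/N=C(/C)c2ccccc2)CC1` differs from compound 3 in one place: a group of 9 heavy atoms (8 carbon, 1 nitrogen; one six-membered aromatic ring of carbon only) in place of a group of 9 heavy atoms (7 carbon, 1 nitrogen, 1 chlorine; one six-membered aromatic ring of carbon only), on an amide-type nitrogen. Among the compounds with values here, two measured steps bear on this. The step of a 1.0-fold lower number from compound 2 to compound 3 (0.02 log units; within the scatter) shows that adding or removing the chloro on the aromatic ring made no difference beyond the scatter. Nothing measured speaks to the extra carbon that enters on the carbon of the double bond outside the aromatic rings, so that part of the change is an open question. The step of a 2.5-fold lower number from compound 1 to compound 2 (0.39 log units; beyond the scatter) shows that the aromatic hydrazone portion as a whole matters modestly, and compound 4 keeps that portion. The expected step of a 1.1-fold higher number from compound 3 to compound 4 (0.02 log units; within the scatter) in this assay is therefore none beyond the scatter. Compound 4 is estimated at 7000 nM, with a range from 3000 nM to 16000 nM.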

Compound 4, concentration for 50% growth inhibition: 14300 nM
The estimate for compound 4 lay 2.0-fold (0.31 log units) below the measured number; the measured number falls inside the stated range.
By their numbers in this assay, from the lowest: compounds 3 and 2 (each within the scatter of the next); then compounds 4 and 1 (each within the scatter of the next).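

The one extra carbon on the double bond outside the aromatic rings is enough to change the result in this assay: the only difference between these two compounds gives a 2.1-fold higher number from compound 2 to compound 4 (0.31 log units; beyond the scatter), so this position is sensitive even to a small addition. Replacing the chloro-bearing group of compound 3 gives a similar shift, a 2.1-fold higher number from compound 3 to compound 4 (0.33 log units; beyond the scatter), while a 1.2-fold lower number from compound 1 to compound 4 (0.08 log units; within the scatter) shows that the aromatic group on the amide-type nitrogen of compound 4 no longer stands apart from the plain end of compound 1. Nothing available here gives a reason for this shift.

Open, from the compounds shown here alone, is whether an ethyl group on that carbon of the double bond would weaken growth inhibition further. Also open, going by these compounds, is whether chloro or an amine on the aromatic ring would change the result once the extra carbon is present.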